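This account rests on a few compounds, and the source may have more. Where it says the series, first, only, none or still open, it means among the compounds named here.

The compounds described here share a core built around a diamino-substituted fused ring system, and they are compared in a functional assay on HL-60 cells (Homo sapiens) for cytotoxicity, read by MTT assay; on this read-out higher numbers stand for weaker inhibition and lower numbers for stronger inhibition. Compound 1, `CCN(CC)c1c(C#N)c(F)c2c(N)nc(N)nc2c1Cl`, carries a chloro group and a diethylamino group on its carbon-only ring; in this assay compound 1 gives 2.3 ug/mL. Compound 2, `CCN(CC)c1c(C#N)c(F)c2c(N)nc(N)nc2c1F`, differs from compound 1 by fluoro in place of chloro on an aromatic carbon; in this assay compound 2 gives 6.4 ug/mL, so the step is a 2.8-fold higher number from compound 1 to compound 2 (0.44 log units; beyond the scatter).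

Compound 3, `N#Cc1c(NCc2ccccc2)c(Cl)c2nc(N)nc(N)c2c1NCc1ccccc1`, belongs to a second set in which the diethylamino group is replaced by two benzylamino groups; how its core differs from that of compound 1 is not broken down here. In this assay compound 3 gives 8.5 ug/mL, the highest of the three numbers, though it lies within the scatter of compound 2 and beyond it only against compound 1.

Compound 4, `N#Cc1c(NCc2ccccc2)c(F)c2nc(N)nc(N)c2c1NCc1ccccc1`, has not yet been measured. It differs from compound 3 by fluoro in place of chloro on an aromatic carbon. This is the same kind of change as that from compound 1 to compound 2, but the surroundings differ: here the place is ortho to a benzylamino group and para to a benzylamino group, whereas in the earlier pair it was ortho to a diethylamino group and para to a fluoro group. Resting on the step from compound 1 to compound 2, the step from compound 3 to compound 4 is expected to be a 2.4-fold higher number from compound 3 to compound 4 (0.37 log units; beyond the scatter), and compound 4 is estimated to give 20 ug/mL in this assay, with a likely range from 7 ug/mL to 55 ug/mL.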

Compound 4, half-maximal inhibitory concentration: 7.2 ug/mL
Compound 4: the middle estimate sits 2.8-fold (0.44 log units) above what was measured, within the range that was stated.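

In this assay, fluoro in place of chloro on the aromatic carbon gives a 1.2-fold lower number from compound 3 to compound 4 (0.07 log units; within the scatter), so on the core of compound 3 this change leaves no difference that can be read. Set beside the earlier pair, the same swap does not carry over from one core to the other with the same size of effect: the same change on two cores in this assay, a 2.8-fold higher number (0.44 log units; beyond the scatter) from compound 1 to compound 2 and a 1.2-fold lower number (0.07 log units; within the scatter) from compound 3 to compound 4, 3.3-fold (0.52 log units) apart, beyond the scatter of two such steps This shows that a step measured on one core was not a safe guide to the other here, but it does not show what sets the two cores apart: they differ in more than one place, and two pairs cannot say which of those differences matters or how the swap would behave on a third core.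

The compounds shown leave open how this assay would respond if that aromatic carbon carried a bromo or a methoxy group instead of chloro or fluoro. They also leave open whether the gap between the two steps would remain on cores that differ in only one place, for instance with a single benzylamino group paired with a diethylamino group, or with a morpholine ring in place of either amine.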